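Taking the benzoyl cap off a side chain

A few compounds are considered here, and "the series" means these few. Any claim that something is new, unique, unknown or untested is made for them only; others in the source may bear on it.

Of the compounds shown here, three sharing one core have been read in a functional assay on MDA-MB-435 cells (Homo sapiens) for cytotoxicity, read by MTT assay, with a stated time of 72 h; on this read-out lower numbers stand for stronger inhibition and higher numbers for weaker inhibition. Compound 1 `CS(=O)(=O)Oc1c(C(=O)NCc2ccc(F)cc2)nc(Br)c2cccnc12` gives > 20000 nM, which is a limit of the assay and not a number. Compound 2 `NCCCNc1c(C(=O)NCc2ccc(F)cc2)nc(Br)c2cccnc12` gives a true number, 5000 nM. Placing (3-aminopropyl)amino where (methylsulfonyl)oxy stood means an at least 4.0-fold lower number from compound 1 to compound 2 (0.60 log units; beyond the scatter). Putting benzoyl in place of hydrogen on an amine nitrogen then means an at least 4.0-fold higher number from compound 2 to compound 3 (0.60 log units; beyond the scatter). Compound 3 `O=C(NCCCNc1c(C(=O)NCc2ccc(F)cc2)nc(Br)c2cccnc12)c1ccccc1` gives > 20000 nM, again only a limit. It therefore stands at the limit of > 20000 nM in this assay, at which 2 of the 3 values shown sit.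

Compound 4 `NCCNc1c(C(=O)NCc2ccc(F)cc2)nc(Br)c2cccnc12` differs from compound 3 by amino in place of benzamidomethyl on a saturated chain carbon, two bonds along the chain from a nitrogen on an aromatic ring. This puts amino in place of benzamidomethyl on a saturated chain carbon, two bonds along the chain from a nitrogen on an aromatic ring. The benzoyl step bears most directly on this change, since it runs the opposite way: an at least 4.0-fold higher number from compound 2 to compound 3 (0.60 log units; beyond the scatter). A fall of similar size is therefore expected in this assay, and the expected change is an at least 3.3-fold lower number from compound 3 to compound 4 (0.52 log units; beyond the scatter). For the measured compounds named here, no measured step covers the difference in chain between compound 2 and compound 4, so the range stays wide. Compound 4 is estimated at 6000 nM, with an expected range of 2500 nM to 15000 nM.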

Compound 4, half-maximal inhibitory concentration: 12000 nM
For compound 4 the middle estimate is 2.0-fold (0.30 log units) below the measured one; the range from low to high includes it.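

In this assay, the length of the side chain counts as well as its free end: with the terminal amine kept and amino in place of aminomethyl on a saturated chain carbon, two bonds along the chain from a nitrogen on an aromatic ring, the result is a 2.4-fold higher number from compound 2 to compound 4 (0.38 log units; beyond the scatter). So a change in the chain alone moves the number by a modest step, which the earlier compounds could not show, as their steps all changed the group itself. The two other new steps each start from a value that is only a limit, so each gives only a floor: an at least 1.6-fold lower number from compound 3 to compound 4 (0.22 log units; that floor lies within the scatter), and an at least 1.6-fold lower number from compound 1 to compound 4 (0.22 log units; that floor lies within the scatter). Both starting values sit at the same limit: the limit of > 20000 nM in this assay, at which 2 of the 4 values shown sit.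

As far as these compounds go, two chain lengths give a direction for compound 2 and compound 4 only, so how a longer chain such as (4-aminobutyl)amino would read stays open. Also open, from the compounds shown here alone, is whether a dimethylamine or a hydroxyl at the chain end could stand in for the free amine.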